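Swapping a tolyl group for naphthyl on the shared core

The source may hold more compounds than are shown below. What is called first, only, known or untested is meant among the compounds shown, and "the series" means these compounds.

Of the compounds shown here, three with a shared core have been tested in a functional assay on KM12 cells (Homo sapiens) for inhibition, read by sulforhodamine B assay, with a stated time of 48 h, tested at 10 uM; on this read-out higher numbers stand for more inhibition at the one concentration tested (going by the name of the read-out) and lower numbers for less inhibition. Compound 1 `Brc1cn2ccnc2c(-c2ccc3ncn(C4CCCCC4)c3c2)n1` carries a bromo group on the core and gives 67.7% in this assay. Compound 2 `Clc1ccc(-c2cn3ccnc3c(-c3ccc4ncn(C5CCCCC5)c4c3)n2)cc1` has a 4-chlorophenyl group in its place, and the result is a number 57.1 percentage points lower from compound 1 to compound 2 (beyond the scatter). Compound 3 `Cc1cccc(-c2cn3ccnc3c(-c3ccc4ncn(Cc5ccccc5)c4c3)n2)c1` differs from compound 2 in two places at once, a 3-methylphenyl group in place of the 4-chlorophenyl and a benzyl group in place of the cyclohexyl, and in this assay compound 3 gives 22.1%. This puts compound 3 second among the three numbers: compared with compound 2, which gives 10.6%, it is somewhat higher, and it lies far below compound 1.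

Compound 4 `c1ccc(Cn2cnc3ccc(-c4nc(-c5cccc6ccccc56)cn5ccnc45)cc32)cc1` is not yet measured. It differs from compound 3 by naphthalen-1-yl in place of 3-methylphenyl on an aromatic carbon. Going by the values given here, no measured step exchanges one aromatic group for another at this position; the only step known, bromo to 4-chlorophenyl, is a number 57.1 percentage points lower from compound 1 to compound 2 (beyond the scatter) and concerns a different kind of change. With nothing directly comparable, the expected step is a number 1.9 percentage points higher from compound 3 to compound 4 (within the scatter), that is, no clear shift beyond the scatter. Compound 4 is therefore estimated at 24%, with a range from 5% to 50%.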

Compound 4, a percentage reported as inhibition, at one concentration (the size of the read-out at that concentration, not a potency): 11%
The estimate for compound 4 lay 13 percentage points above the measured number; measured number inside the range.
By their numbers in this assay, from the lowest: compounds 2 and 4 (each within the scatter of the next); then compound 3; then compound 1.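

In this assay, the exchange of 3-methylphenyl for naphthalen-1-yl, which brings a second six-membered aromatic ring of carbon only, gives a number 11.1 percentage points lower from compound 3 to compound 4 (beyond the scatter). This shows that the position responds to which aromatic group it carries, and not only to whether it carries one at all, which was the kind of change seen in the earlier step, a number 57.1 percentage points lower from compound 1 to compound 2 (beyond the scatter). The new step is the smaller of the two, and neither group in it has hydrogen-bond donors or acceptors, but nothing available here accounts for the lower number.

The compounds shown leave open whether a group of another kind at this position, such as a small amine like morpholine or a carboxylic acid, would bring the number back towards that of compound 1 at 67.7%. Also open, going by these compounds, is whether the same exchange of 3-methylphenyl for naphthalen-1-yl would give a similar step with the cyclohexyl group of compound 2 in place of the benzyl group.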